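The source may report more compounds than this note shows. Statements on the series, on what has been measured and on what is new or still open speak of the compounds shown alone.

Measured so far in an assay on COS-7 cells for inhibition of patatin-like phospholipase domain-containing protein 2 (Mus musculus); a lower number here means a stronger inhibitor, a higher number a weaker inhibitor:
compound 1 `CCOc1ccc(-c2cccc(S(=O)(=O)N(C)C)c2)cc1` gives 110000 nM;
compound 2 `CCOc1ccc(-c2cccc(S(=O)(=O)NC)c2)cc1` gives 200000 nM;
compound 3 `CCOc1ccc(-c2cccc(C(=O)OCCOC)c2)cc1` gives 70000 nM.

Compound 3 holds the lowest of the three numbers: a 1.6-fold lower number from compound 1 to compound 3 (0.20 log units; within the scatter), and a 2.9-fold lower number from compound 2 to compound 3 (0.46 log units; beyond the scatter). Compound 4 `CCOc1ccc(-c2cccc([N+](=O)[O-])c2)cc1` differs from compound 3 by nitro in place of (2-methoxyethoxy)carbonyl on an aromatic carbon. The two exchanges already measured at this same aromatic carbon, a 1.6-fold lower number from compound 1 to compound 3 (0.20 log units; within the scatter) and a 2.9-fold lower number from compound 2 to compound 3 (0.46 log units; beyond the scatter), were both small, so only a modest step in this assay is expected for the move to compound 4, with a higher number somewhat more likely, since compound 3 gives 70000 nM, the lowest of the three. Compound 4 is therefore estimated at 120000 nM, between 50000 nM and 300000 nM, which means a 1.7-fold higher number from compound 3 to compound 4 (0.23 log units; within the scatter).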

Compound 4, half-maximal inhibitory concentration: > 200000 nM
Compound 4 gave a limit, no number; the forecaster's own chance of this, stated with the estimate: 15%; middle value at least 1.6-fold (0.22 log units) away from the limit.
By their numbers in this assay, from the lowest: compounds 3, 1 and 2 (each within the scatter of the next, the first and the last beyond it).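

In this assay, going by these compounds alone, putting nitro, the group with fewer heavy atoms, in place of (2-methoxyethoxy)carbonyl on this aromatic carbon gives an at least 2.8-fold higher number from compound 3 to compound 4 (0.45 log units; beyond the scatter), the first exchange here that brings no lower number than compound 3 while shortening the substituent. The reading for compound 4 is a limit and not a number: the limit of > 200000 nM in this assay, at which 1 of the 4 values shown sits. Against the dimethylsulfamoyl group the change reads as an at least 1.8-fold higher number from compound 1 to compound 4 (0.25 log units; that floor lies within the scatter), and against the methylsulfamoyl group it reads as a number no lower from compound 2 to compound 4 (the limit leaves the size open).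

On these data alone, whether an amine or a carboxylic acid on this carbon would give a lower number than compound 3 stays open. As far as these compounds go, how far compound 4 lies past its limit also stays open.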